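The source may hold more compounds than are shown below. What is called first, only, known or untested is meant among the compounds shown, and "the series" means these compounds.

Three compounds built on a shared core were tested in a functional assay on A549 cells (Homo sapiens) for antiproliferative activity, read by CCK-8 assay, with a stated time of 72 h; on this read-out lower numbers stand for stronger inhibition and higher numbers for weaker inhibition. Compound 1 `O=C(Nc1cccc(-c2oc3cc(-c4ccc(F)cc4)ccc3c(=O)c2O)c1)c1ccc(C(F)(F)F)cc1` gives 19400 nM. Compound 2 `O=C(Nc1cccc(-c2oc3cc(-c4ccc(F)cc4)ccc3c(=O)c2O)c1)c1ccc(Br)cc1` gives 13500 nM. Compound 3 `COc1cccc(C(=O)Nc2cccc(-c3oc4cc(-c5ccc(F)cc5)ccc4c(=O)c3O)c2)c1` gives 10800 nM. The steps among them are small: a 1.4-fold lower number from compound 1 to compound 2 (0.16 log units; within the scatter), a 1.8-fold lower number from compound 1 to compound 3 (0.25 log units; within the scatter), and a 1.3-fold lower number from compound 2 to compound 3 (0.10 log units; within the scatter). Compound 3 thus carries the lowest of the three numbers, yet all three values lie within the usual scatter of one another, so none of these compounds can be called more or less potent than another.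

Compound 4 `O=C(Nc1cccc(-c2oc3cc(-c4ccc(F)cc4)ccc3c(=O)c2O)c1)c1ccc(-c2ccccc2)cc1` has not yet been measured. It differs from compound 3 in one place: 4-phenylphenyl in place of 3-methoxyphenyl on a carbonyl carbon. Among the measured compounds shown here, no measured step mirrors this change exactly. What the three steps do show is that exchanging one aryl group for another on the carbonyl carbon, or bromo for trifluoromethyl on an aromatic carbon, moved the number by less than the scatter each time. On that basis the step of a 1.0-fold higher number from compound 3 to compound 4 (0.01 log units; within the scatter) is expected to stay small, with no clear direction, though the 4-phenylphenyl group lies outside what the three examples cover, which widens the uncertainty. Compound 4 is therefore estimated at 11000 nM, with a range from 4000 nM to 30000 nM.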

Compound 4, half-maximal inhibitory concentration: > 100000 nM
Compound 4: only a limit was reported; the forecaster's own chance of this, stated with the estimate: 10%; at least 9.0-fold (0.95 log units) between middle value and limit.
By their numbers in this assay, from the lowest: compounds 3, 2 and 1 (each within the scatter of the next). At a limit, above all of these: compound 4.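

In this assay compound 4 gives only a limit, > 100000 nM, not a number, so each step to it fixes a minimum size and not an exact one. Even so, the earlier exchanges of one aryl group for another on the carbonyl carbon stayed within the scatter, whereas this change does not: 4-phenylphenyl in place of 3-methoxyphenyl gives an at least 9.2-fold higher number from compound 3 to compound 4 (0.96 log units; beyond the scatter), phenyl in place of bromo gives an at least 7.4-fold higher number from compound 2 to compound 4 (0.86 log units; beyond the scatter), and phenyl in place of trifluoromethyl gives an at least 5.1-fold higher number from compound 1 to compound 4 (0.71 log units; beyond the scatter), all beyond the scatter, which shows that this part of the molecule is not free to take any aryl group. The data give no cause for this loss, and the only further fact at hand is how the limit stands among the results: the limit of > 100000 nM in this assay, at which 1 of the 4 values shown sits.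

On these data alone, the exact size of these steps stays open, and so does the question of whether the second phenyl ring itself matters or would matter less if joined through a longer chain. Also open, as far as these compounds go, is how a phenyl ring carrying an amine or a carboxylic acid would behave on the same carbonyl carbon.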